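A few compounds are considered here, and "the series" means these few. Any claim that something is new, unique, unknown or untested is made for them only; others in the source may bear on it.

In a functional assay on KBVIN cells (Homo sapiens) for antiproliferative activity, read by sulforhodamine B assay, with a stated time of 3 days (a lower number here means a stronger inhibitor of growth, a higher number a weaker inhibitor of growth), compound 1 `O=C(Nc1ccccn1)c1cccc(Nc2ncc(F)c(Nc3ccc(F)cc3)n2)c1` gives 13700 nM, compound 2 `COc1ccc(NC(=O)c2cccc(Nc3ncc(F)c(Nc4ccc(F)cc4)n3)c2)cc1` gives 15700 nM and compound 3 `O=C(Nc1cc(Cl)cc(Cl)c1)c1cccc(Nc2ncc(F)c(Nc3ccc(F)cc3)n2)c1` gives 20700 nM, so compound 3 stands within the scatter of both others. Compound 4 `COc1cc(NC(=O)c2cccc(Nc3ncc(F)c(Nc4ccc(F)cc4)n3)c2)cc(OC)c1` has 3,5-dimethoxyphenyl in place of 3,5-dichlorophenyl on an amide-type nitrogen. Three measured steps changed the group at this same place, and all stayed within the scatter: a 1.1-fold higher number from compound 1 to compound 2 (0.06 log units; within the scatter), a 1.5-fold higher number from compound 1 to compound 3 (0.18 log units; within the scatter) and a 1.3-fold higher number from compound 2 to compound 3 (0.12 log units; within the scatter). The last, which also joins a methoxy-bearing phenyl and compound 3, bears most closely, so no step beyond the scatter is expected in this assay. The expected result is a 1.3-fold lower number from compound 3 to compound 4 (0.11 log units; within the scatter). For compound 4 the estimate is 16000 nM, with an expected range of 9000 nM to 27000 nM.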

Compound 4, concentration for 50% growth inhibition: 12700 nM
Compound 4: the middle estimate sits 1.3-fold (0.10 log units) above what was measured; the range from low to high includes it.
By their numbers in this assay, from the lowest: compounds 4, 1, 2 and 3 (each within the scatter of the next).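

In this assay the change to 3,5-dimethoxyphenyl gives a 1.6-fold lower number from compound 3 to compound 4 (0.21 log units; within the scatter) and a 1.2-fold lower number from compound 2 to compound 4 (0.09 log units; within the scatter) and a 1.1-fold lower number from compound 1 to compound 4 (0.03 log units; within the scatter) and so stays within the scatter of all three earlier groups. Two methoxy groups on the phenyl ring, with the 2 hydrogen-bond acceptors counted for this group and none for 3,5-dichlorophenyl, therefore produce no step beyond the scatter on the amide-type nitrogen. Nothing available explains this result. As far as these compounds go, whether an aminoalkyl chain or a carboxylic acid on this phenyl ring would move the number beyond the scatter remains open.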